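Sulfonyl to sulfanyl in a growth-inhibition series

The source may hold more compounds than are shown below. What is called first, only, known or untested is meant among the compounds shown, and "the series" means these compounds.

In a functional assay on DU-145 cells (Homo sapiens) for inhibition, read by trypan blue exclusion, with a stated time of 96 h (a lower number here means a stronger inhibitor of growth, a higher number a weaker inhibitor of growth), compound 1 (`COc1cc(OC)c(/C=C(/C(=O)c2ccc(Cl)cc2)[S+]([O-])Cc2ccccc2Cl)c(OC)c1`) gives 10000 nM as its concentration for half-maximal growth inhibition.

Compound 2 (`COc1cc(OC)c(/C=C(/C(=O)c2ccc(Cl)cc2)S(=O)(=O)Cc2ccccc2Cl)c(OC)c1`) gives only a limit of the assay (> 100000 nM) and no number.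

Compound 3 (`COc1cc(OC)c(/C=C(\SCc2ccccc2Cl)C(=O)c2ccc(Cl)cc2)c(OC)c1`) differs from compound 2 at one place ((2-chlorobenzyl)sulfanyl in place of (2-chlorobenzyl)sulfonyl on a double-bonded chain carbon bound to a carbonyl carbon and a double-bonded chain carbon): (2-chlorobenzyl)sulfanyl stands in place of (2-chlorobenzyl)sulfonyl on a double-bonded chain carbon bound to a carbonyl carbon and a double-bonded chain carbon. Among the compounds with values here, one measured step bears on this change, at the same place (an at least 10-fold higher number from compound 1 to compound 2 (1.00 log units; beyond the scatter)), and its size is open-ended. Away from the sulfonyl group, compound 1 (10000 nM) holds the lower number, so the same direction is expected here, although a single step leaves the size uncertain. The expected step is an at least 16-fold lower number from compound 2 to compound 3 (1.22 log units; beyond the scatter) and it should lie beyond the scatter. In this assay compound 3 is estimated at 6000 nM (range 800 nM to 40000 nM).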

Compound 3, concentration for 50% growth inhibition: 25000 nM
Compound 3: middle estimate off by 4.2-fold (0.62 log units), on the low side, within the range that was stated.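

At this place, on a double-bonded chain carbon bound to a carbonyl carbon and a double-bonded chain carbon, (2-chlorobenzyl)sulfanyl in place of (2-chlorobenzyl)sulfonyl gives an at least 4.0-fold lower number from compound 2 to compound 3 (0.60 log units; beyond the scatter), so the sulfanyl compound does not share the loss seen with the sulfonyl group. The group of compound 1 still holds the lower number, with a 2.5-fold higher number from compound 1 to compound 3 (0.40 log units; beyond the scatter), so among these three compounds the number does not rise steadily with the oxygens on sulfur. The step from compound 2 stays open-ended in size, because compound 2 gives a limit and not a number: the limit of > 100000 nM in this assay, at which 1 of the 3 values shown sits.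

The compounds shown leave open whether an amine or a carboxylic acid at this place would go lower than compound 1. They also leave open whether a longer chain in place of the (2-chlorobenzyl)sulfanyl group would keep this order.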